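Phenyl for methyl on the saturated ring carbon

The source may hold more compounds than are shown below. What is called first, only, known or untested is meant among the compounds shown, and "the series" means these compounds.

Of the compounds shown here, two have been tested in a functional assay on SK-BR-3 cells (Homo sapiens) for inhibition, read by sulforhodamine B assay, with a stated time of 48 h; on this read-out lower numbers stand for stronger inhibition and higher numbers for weaker inhibition. Compound 1 `CO[C@@H]1CC=C2NN(c3cc(F)cc(Cl)c3)C(=O)C[C@]2(c2ccccc2)O1` gives 17600 nM, and compound 2 `CO[C@@H]1CC=C2NN(c3cncnc3)C(=O)C[C@]2(C)O1` gives 3400 nM. Of the two numbers, that of compound 2 is the lower, and the gap to compound 1 lies beyond the scatter; since compound 1 and compound 2 differ in two places at once, the share of each place in that gap cannot be read from these values alone.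

Compound 3 `CO[C@@H]1CC=C2NN(c3cncnc3)C(=O)C[C@]2(c2ccccc2)O1` keeps the aryl group on nitrogen of compound 2 and changes only the saturated ring carbon: phenyl in place of methyl on a saturated ring carbon. Within the data shown here, with no measured pair isolating this change, the size of the step is expected to be modest and its direction uncertain, most likely toward a somewhat higher number. The expected step is a 1.8-fold higher number from compound 2 to compound 3 (0.25 log units; within the scatter). Compound 3 is therefore estimated at 6000 nM, with a range from 1500 nM to 25000 nM.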

Compound 3, half-maximal inhibitory concentration: 5300 nM
For compound 3 the middle estimate is 1.1-fold (0.05 log units) above the measured one; measured number inside the range.
By their numbers in this assay, from the lowest: compounds 2 and 3 (each within the scatter of the next); then compound 1.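

In this assay the swap of methyl for phenyl on the saturated ring carbon next to the ring oxygen gives a 1.6-fold higher number from compound 2 to compound 3 (0.19 log units; within the scatter) and so shows no difference that stands out from the scatter at this position. With phenyl held constant, pyrimidin-5-yl in place of 3-chloro-5-fluorophenyl on the amide-type nitrogen gives a 3.3-fold lower number from compound 1 to compound 3 (0.52 log units; beyond the scatter) and, unlike the change at the carbon, lies beyond the scatter, so this pair places a measurable effect on the nitrogen substituent, which compound 1 and compound 2 alone could not do. Nothing available explains either step.

Going by these compounds, whether a longer chain or a carboxylic acid on that ring carbon would read like methyl and phenyl stays open. So does the value that a pyridin-3-yl group on the amide-type nitrogen would give.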